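The source may hold more compounds than are shown below. What is called first, only, known or untested is meant among the compounds shown, and "the series" means these compounds.

Measured compounds:
compound 1 `COc1c(Br)cc(Br)cc1C(=O)Nc1ccc(Sc2nc3ccccc3s2)c(Cl)c1` — > 100000 nM (a limit)
compound 2 `O=C(Nc1ccc(Sc2nc3ccccc3s2)c(Cl)c1)c1cccc(Br)c1` — > 100000 nM (a limit)

In an assay for inhibition of HSP60/HSP10 (Homo sapiens), with a stated time of 60 min (a lower number here means a stronger inhibitor, a higher number a weaker inhibitor), compound 1 gives > 100000 nM, which is a limit of the assay rather than a number. Compound 2 gives > 100000 nM, again only a limit. The step that the two limits leave unreadable from compound 1 to compound 2 therefore cannot be read in size or direction. Both values shown sit at the limit of > 100000 nM in this assay, at which 2 of the 2 values shown sit, so compound 2 stands nowhere more precisely than at that limit.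

Compound 3 `O=C(Nc1ccc(Sc2nc3ccccc3s2)c(Cl)c1)c1cc(Br)cc(Br)c1O` differs from compound 2 by 3,5-dibromo-2-hydroxyphenyl in place of 3-bromophenyl on a carbonyl carbon. Among the measured compounds shown here, no measured step bears on this change in a readable way, since both values in this assay are limits. The estimate for compound 3 is therefore an expected step that the limit leaves unreadable from compound 2 to compound 3 that stays within the scatter, and compound 3 is expected to give 150000 nM, with a range from 20000 nM to 1000000 nM, most likely reported again only as a limit.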

Compound 3, half-maximal inhibitory concentration: 4200 nM
Beside the measured number, compound 3's estimate is 36-fold (1.55 log units) above it, and the stated range ends above it.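

In this assay, putting hydrogen in place of methyl on the oxygen on the aromatic ring gives an at least 23-fold lower number from compound 1 to compound 3 (1.37 log units; beyond the scatter), so this single change turns a compound at the limit into one with a readable number. Going from 3-bromophenyl to 3,5-dibromo-2-hydroxyphenyl on the carbonyl carbon gives an at least 23-fold lower number from compound 2 to compound 3 (1.37 log units; beyond the scatter), yet compound 1 carries both bromines and still reads only as a limit, so here the bromines alone do not give a readable number. Compound 3 is the only readable value so far, and the step from compound 1 to compound 2 cannot be read: the limit of > 100000 nM in this assay, at which 2 of the 3 values shown sit.

Whether the hydroxy group needs either bromine stays open, since a 2-hydroxyphenyl group without bromine is not among the compounds shown. So does how an amine or a carboxylic acid would read in that place.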